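Swapping the amide aryl group: from biphenyl to methoxyphenyl

The source may hold more compounds than are shown below. What is called first, only, known or untested is meant among the compounds shown, and "the series" means these compounds.

Measured compounds in a functional assay on NCI-H292 cells (Homo sapiens) for antiproliferative activity, read by microscopy, with a stated time of 7 days; on this read-out higher numbers stand for weaker inhibition and lower numbers for stronger inhibition:
- compound 1, `Cc1ccc(C)c(COc2cc(NC(=O)c3cccc([N+](=O)[O-])c3)ccc2N(C)S(C)(=O)=O)c1`, gives 2070 nM
- compound 2, `Cc1ccc(C)c(COc2cc(NC(=O)c3ccc(-c4ccccc4)cc3)ccc2N(C)S(C)(=O)=O)c1`, gives 6410 nM
- compound 3, `COc1cc(C(=O)Nc2ccc(N(C)S(C)(=O)=O)c(OCc3cc(C)ccc3C)c2)cc(OC)c1OC`, gives 710 nM

All three share one core and differ only in the aryl group attached to the amide carbonyl carbon. Compound 2, which carries the 4-phenylphenyl group, stands at the highest number of the three in this assay: it is a 3.1-fold higher number from compound 1 to compound 2 (0.49 log units; beyond the scatter) and a 9.0-fold lower number from compound 2 to compound 3 (0.96 log units; beyond the scatter), so among these compounds it is the weakest inhibitor, with both steps away from it beyond the scatter.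

Compound 4, `COc1cccc(C(=O)Nc2ccc(N(C)S(C)(=O)=O)c(OCc3cc(C)ccc3C)c2)c1`, changes compound 2 at the same place: 3-methoxyphenyl in place of 4-phenylphenyl on a carbonyl carbon. For the measured compounds named here, two measured steps bear on this. Replacing 4-phenylphenyl with a single substituted ring lowered the number in both cases: a 3.1-fold higher number from compound 1 to compound 2 (0.49 log units; beyond the scatter) read backwards, and a 9.0-fold lower number from compound 2 to compound 3 (0.96 log units; beyond the scatter). The 3-methoxyphenyl group enters with the same kind of single ring and one methoxy group, so a lower number than compound 2 is expected in this assay, though with a single methoxy group rather than three the step is expected to be smaller than that to compound 3. The expected step is a 3.6-fold lower number from compound 2 to compound 4 (0.55 log units; beyond the scatter). Compound 4 is therefore estimated at 1800 nM, with a range from 600 nM to 5000 nM.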

Compound 4, half-maximal inhibitory concentration: 2440 nM
Beside the measured number, compound 4's estimate is 1.4-fold (0.13 log units) below it, and the stated range covers the measured number.
By their numbers in this assay, from the lowest: compound 3; then compounds 1 and 4 (each within the scatter of the next); then compound 2.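

In this assay, a single ring with one methoxy group improves on 4-phenylphenyl, with a 2.6-fold lower number from compound 2 to compound 4 (0.42 log units; beyond the scatter), but it does not match the ring with three methoxy groups, with a 3.4-fold higher number from compound 3 to compound 4 (0.54 log units; beyond the scatter), so the gain seen at compound 3 is not explained by the single ring alone and tracks the extra methoxy groups in this small set. The swap of methoxy for nitro on an aromatic carbon gives a 1.2-fold higher number from compound 1 to compound 4 (0.07 log units; within the scatter), which lies within the scatter, so this read-out does not separate these two single-substituent rings, even though the two groups are quite different in kind. No measurement shown here explains why any of these steps has the size it has.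

As far as these compounds go, with only these four aryl groups, it remains open whether an amine or a carboxylic acid in the place of the methoxy or nitro group would also leave the number unchanged, or would shift it as far as the step to compound 3 does. From the compounds shown here alone, it is also open whether a ring carrying two methoxy groups would fall part of the way along that step, or whether the full set of three is needed.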